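Aryl fluorination pattern on the shared core and growth inhibition

The compounds below may be only part of what the source reports. "The series", "measured", "known", "first", "only" and "open" are said of these compounds alone.

Compound 1 `OC[C@H]1O[C@@H](n2cnc3c(NCc4ccc(F)cc4)ncnc32)[C@H](O)[C@@H]1O`: in a functional assay on K562 cells (Homo sapiens) for antiproliferative activity, with a stated time of 72 h (on this read-out lower numbers stand for stronger inhibition and higher numbers for weaker inhibition), compound 1 gives 2700 nM.
Compound 2 `COc1cccc(CNc2ncnc3c2ncn3[C@@H]2O[C@H](CO)[C@@H](O)[C@H]2O)c1OC`: in this assay compound 2 reaches only a limit, > 166000 nM.
Compound 3 `OC[C@H]1O[C@@H](n2cnc3c(NCc4ccc(F)cc4F)ncnc32)[C@H](O)[C@@H]1O`: in this assay compound 3 gives 9600 nM.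

Within the data shown here, of the two numbers measured so far, compound 1 stands lowest; its nearest neighbour is compound 3, with a 3.6-fold higher number from compound 1 to compound 3 (0.55 log units; beyond the scatter). For compound 2 only a limit is known (the limit of > 166000 nM in this assay, at which 1 of the 3 values shown sits), so an at least 61-fold higher number from compound 1 to compound 2 (1.78 log units; beyond the scatter) and an at least 17-fold lower number from compound 2 to compound 3 (1.23 log units; beyond the scatter) are bounds rather than exact steps.

Compound 4 `OC[C@H]1O[C@@H](n2cnc3c(NCc4c(F)ccc(F)c4F)ncnc32)[C@H](O)[C@@H]1O` differs from compound 1 by 2,3,6-trifluorophenyl in place of 4-fluorophenyl on a saturated chain carbon bound to a nitrogen on an aromatic ring. Among the measured compounds shown here, the one measured step that bears directly on this change is the addition of fluoro to the aromatic ring, a 3.6-fold higher number from compound 1 to compound 3 (0.55 log units; beyond the scatter), a modest weakening in this assay. The large steps involving compound 2 concern a 2,3-dimethoxyphenyl group and so speak only loosely to fluorination. Compound 4 takes the fluorination further than compound 3, so a weakening somewhat larger than that seen for compound 3 is expected, though the bound for compound 2 should not be approached. For compound 4 the expected step is a 5.6-fold higher number from compound 1 to compound 4 (0.74 log units; beyond the scatter). Compound 4 is therefore estimated at 15000 nM, with a range from 5000 nM to 60000 nM.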

Compound 4, half-maximal inhibitory concentration: > 166000 nM
Compound 4 ended at the assay's limit; the forecaster's own chance of this, stated with the estimate: 5%; middle value at least 11-fold (1.04 log units) away from the limit.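

Replacing 4-fluorophenyl with 2,3,6-trifluorophenyl on a saturated chain carbon bound to a nitrogen on an aromatic ring has a far larger effect in this assay than the earlier fluorination, which gave only a 3.6-fold higher number from compound 1 to compound 3 (0.55 log units; beyond the scatter), whereas this change gives an at least 61-fold higher number from compound 1 to compound 4 (1.78 log units; beyond the scatter). Activity at this position therefore does not fall away gently across the fluorinated compounds: the change from 2,4-difluorophenyl to 2,3,6-trifluorophenyl alone gives an at least 17-fold higher number from compound 3 to compound 4 (1.23 log units; beyond the scatter), so this group, with no methoxy group on it, ends in the same place as the 2,3-dimethoxyphenyl group of compound 2. The result for compound 4 is a limit and not a number, so both steps above are bounds, and the step between compound 2 and compound 4 cannot be read: the limit of > 166000 nM in this assay, at which 2 of the 4 values shown sit.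

The number of fluoro groups and their placement change together in compounds 1, 3 and 4, so the compounds shown cannot separate the two. Also open, from the compounds shown here alone, is how this position responds to an unsubstituted phenyl or to 4-chlorophenyl, which would show whether the 4-fluorophenyl of compound 1 has any special standing on the shared core.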